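The compounds below may be only part of what the source reports. "The series", "measured", "known", "first", "only" and "open" are said of these compounds alone.

Working notes on the series. Compound 2 `COc1cc(-c2nnc(SCC(=O)c3ccccc3)n2N2C(=O)c3ccccc3C2=O)cc(OC)c1OC` is measured in a functional assay on HepG2 cells (Homo sapiens) for cytotoxicity, read by MTT assay, with a stated time of 48 h (a higher number here means a weaker inhibitor, a lower number a stronger inhibitor), at 171000 nM, the higher of the two numbers in hand; the only comparator, compound 1 `COc1cc(-c2nnc(SCC(=O)c3ccc(Cl)cc3)n2N2C(=O)c3ccccc3C2=O)cc(OC)c1OC`, gives 22000 nM in this assay. For the measured compounds named here, the single step that connects them is a 7.8-fold higher number from compound 1 to compound 2 (0.89 log units; beyond the scatter), so removal of the halogen from the aryl ketone ring raised the number beyond the scatter.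

Compound 3 `COc1cc(-c2nnc(SCC(=O)c3ccc(F)c(F)c3)n2N2C(=O)c3ccccc3C2=O)cc(OC)c1OC` differs from compound 2 by 3,4-difluorophenyl in place of phenyl on a carbonyl carbon. The step from compound 1 to compound 2 bears directly on this change, as it also alters halogen substitution on the same ring attached to the carbonyl carbon, and it was modest in size. Compound 3 is therefore expected to give a lower number than compound 2 in this assay, by a step of roughly a 3.8-fold lower number from compound 2 to compound 3 (0.58 log units; beyond the scatter), since compound 1 with its chloro on that ring gave 22000 nM. Whether two fluorines match one chloro is not shown by the data, so the expectation is kept wide: compound 3 is estimated at 45000 nM, with a range from 15000 nM to 140000 nM.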

Compound 3, half-maximal inhibitory concentration: > 200000 nM
Compound 3: only a limit was reported; the forecaster's own chance of this, stated with the estimate: 5%; middle value at least 4.4-fold (0.64 log units) away from the limit.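

The reading for compound 3 in this assay is a limit, not a number: the limit of > 200000 nM in this assay, at which 1 of the 3 values shown sits. Halogen on the ring attached to the carbonyl carbon therefore does not by itself bring the number down: 3,4-difluorophenyl in place of 4-chlorophenyl gives an at least 9.0-fold higher number from compound 1 to compound 3 (0.95 log units; beyond the scatter), so among the three compounds the low number stays with 4-chlorophenyl alone, and compound 3 goes against any reading of the earlier step as a general halogen trend. Against the unsubstituted phenyl, the change gives an at least 1.1-fold higher number from compound 2 to compound 3 (0.06 log units; that floor lies within the scatter); as that floor lies within the scatter, 3,4-difluorophenyl cannot be placed in order against phenyl, though it shows none of the drop seen with 4-chlorophenyl.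

The compounds shown leave open whether the chloro itself or its place on the ring carries the lower number, a question that a single bromo or a single fluoro on that ring, or a methoxy group in the same place, would begin to answer. They also leave open how far the number of compound 3 actually lies from that of compound 2 in this assay.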